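Cyano to methoxy on the shared core

The compounds below may be only part of what the source reports. "The series", "measured", "known", "first", "only" and "open" are said of these compounds alone.

The three measured compounds share one core and differ at a single aromatic carbon. Compound 1 `O=C(Nc1cccc(Cl)c1)C(Cl)Cl` gives 14800 nM in a functional assay on A549 cells (Homo sapiens) for antiproliferative activity, read by MTT assay, with a stated time of 72 h; a higher number here means a weaker inhibitor, a lower number a stronger inhibitor. Compound 2 `O=C(Nc1cccc(I)c1)C(Cl)Cl` gives 4760 nM in this assay, and compound 3 `N#Cc1cccc(NC(=O)C(Cl)Cl)c1` gives 66500 nM in this assay. Compound 3 therefore stands highest of the three: the step of a 4.5-fold higher number from compound 1 to compound 3 (0.65 log units; beyond the scatter) and the step of a 14-fold higher number from compound 2 to compound 3 (1.15 log units; beyond the scatter) both run upward and beyond the scatter, while a 3.1-fold lower number from compound 1 to compound 2 (0.49 log units; beyond the scatter) runs the other way between the two halogens.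

Compound 4 `COc1cccc(NC(=O)C(Cl)Cl)c1` is not yet measured; its change from compound 3 is methoxy in place of cyano on an aromatic carbon. Within the data shown here, none of the measured steps swaps cyano for methoxy, so no step bears on it directly. What the series shows is that both halogens give lower numbers than cyano, with compound 3 the highest at 66500 nM; the steps of a 4.5-fold higher number from compound 1 to compound 3 (0.65 log units; beyond the scatter) and a 14-fold higher number from compound 2 to compound 3 (1.15 log units; beyond the scatter) mark out the span that a change at this carbon has covered so far, and methoxy is neither halogen nor cyano. On that basis compound 4 is expected to come out lower than compound 3, by a step of roughly a 3.3-fold lower number from compound 3 to compound 4 (0.52 log units; beyond the scatter) in this assay. The estimate for compound 4 is 20000 nM, with a range from 5000 nM to 80000 nM.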

Compound 4, half-maximal inhibitory concentration: 25800 nM
For compound 4 the middle estimate is 1.3-fold (0.11 log units) below the measured one; the measured number falls inside the stated range.
By their numbers in this assay, from the lowest: compound 2; then compounds 1 and 4 (each within the scatter of the next); then compound 3.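

Working notes on the series, in this assay: cyano and methoxy have equal counts of heavy atoms and hydrogen-bond acceptors as printed for the two groups, yet the swap still gives a step beyond the scatter (a 2.6-fold lower number from compound 3 to compound 4 (0.41 log units; beyond the scatter)), so those counts alone do not fix the reading at this aromatic carbon. The halogens also no longer stand apart as a class, since methoxy cannot be told from chloro (a 1.7-fold higher number from compound 1 to compound 4 (0.24 log units; within the scatter)) but remains well separated from iodo (a 5.4-fold higher number from compound 2 to compound 4 (0.73 log units; beyond the scatter)); of the four groups, only iodo holds the low end and only cyano the high end, each beyond the scatter of all the others. No measurement among the data shown accounts for any of these differences.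

As far as these compounds go, whether an amine, a carboxylic acid or a longer chain such as ethoxy at this carbon would fall within the span from compound 2 to compound 3 or outside it remains open. Also open, from the compounds shown here alone, is whether this order of groups would hold at another carbon of the aromatic ring or on a different cell line.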